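A Methyl Group Added to Compound 1: What to Expect

This account rests on a few compounds, and the source may have more. Where it says the series, first, only, none or still open, it means among the compounds named here.

Compound 1 `N/C(=N\NC(=S)N1CCOCC1)c1ccccn1` was tested in a functional assay on MCF7 cells (Homo sapiens) for cytotoxicity, read by MTT assay, with a stated time of 72 h, tested at 100 uM (on this read-out lower numbers stand for less inhibition of growth and higher numbers for more inhibition of growth at the one concentration tested), where compound 1 gives 81.6%. For the measured compounds named here, the only other measured compound, compound 2 `N/C(=N\NC(=S)N1CCN(c2ccccn2)CC1)c1ccc(F)cn1`, gives 74.3% in this assay. Compound 1 holds the higher of the two numbers, but its gap to compound 2 lies within the usual scatter, so the two cannot be told apart on these numbers. Compound 3 `Cc1ccnc(/C(N)=N/NC(=S)N2CCOCC2)c1` has not yet been measured. It differs from compound 1 by one change only: methyl in place of hydrogen on an aromatic carbon, on a six-membered aromatic ring with one nitrogen, meta to a large group and opposite the ring nitrogen. Going by the values given here, no pair of measured compounds differing in one place is available to show what such a change does here, so nothing points in either direction. The step of a number 3.6 percentage points lower from compound 1 to compound 3 (within the scatter) is therefore expected to stay within the scatter. For compound 3 the estimated value is 78%, expected to fall between 60% and 92%.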

Compound 3, percent growth inhibition at one concentration: 12.8%
Estimate against measurement, compound 3: 65.2 percentage points above; the whole stated range lies above it.
By their numbers in this assay, from the lowest: compound 3; then compounds 2 and 1 (each within the scatter of the next).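

In this assay the exchange of hydrogen for methyl on an aromatic carbon, meta to a large group and opposite the ring nitrogen, gives a number 68.8 percentage points lower from compound 1 to compound 3 (beyond the scatter) and so removes most of the growth inhibition seen with the parent compound. For the compounds shown here, until now no pair of compounds differing in one place was available, and this first pair shows that the position is far from indifferent: adding a single carbon atom, with no ring, no charge and no hydrogen-bond donors or acceptors, is enough to produce a large step at the one concentration tested. Nothing at hand explains why this small change has so large an effect, so the step stands as an observation only.

As far as these compounds go, what remains open is whether any group at this carbon gives the same loss, or whether a fluorine atom, a hydroxyl group, a methoxy group or an amine would keep more of the activity of compound 1. From the compounds shown here alone, it is also open whether methyl on one of the other ring carbons would give a step of similar size, or whether the drop belongs to this one place.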